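Replacing methyl with dimethylamino on the fused core

The compounds below may be only part of what the source reports. "The series", "measured", "known", "first", "only" and "open" are said of these compounds alone.

Compound 3, `Cc1ncnc2c1c(-c1ccsc1)cn2[C@@H]1O[C@H](CO)[C@@H](O)[C@H]1O`, gives 350 nM in a functional assay on HL-60 cells (Homo sapiens) for antiproliferative activity, read by XTT assay, with a stated time of 72 h (on this read-out lower numbers stand for stronger inhibition and higher numbers for weaker inhibition), the highest of the two numbers shown, with compound 2 as its nearest neighbour. For the measured compounds named here, compound 2, `COc1ncnc2c1c(-c1ccsc1)cn2[C@@H]1O[C@H](CO)[C@@H](O)[C@H]1O`, gives 130 nM in this assay, and the only measured step in this set, a 2.7-fold higher number from compound 2 to compound 3 (0.43 log units; beyond the scatter), is modest. Compound 1, `CN(C)c1ncnc2c1c(-c1cc3ccccc3o1)cn2[C@@H]1O[C@H](CO)[C@@H](O)[C@H]1O`, carries a dimethylamino group on the same ring position together with a different aryl group, and in this assay compound 1 reaches only the limit > 20000 nM, which is a limit of the assay and not a number (the limit of > 20000 nM in this assay, at which 1 of the 3 values shown sits). Compound 4, `CN(C)c1ncnc2c1c(-c1ccsc1)cn2[C@@H]1O[C@H](CO)[C@@H](O)[C@H]1O`, differs from compound 3 by dimethylamino in place of methyl on an aromatic carbon. Going by the values given here, no measured step covers this change directly, so the expectation rests on compound 1, which shares the dimethylamino group and sits at the limit, and on the modest size of the methyl-for-methoxy step. Compound 4 is therefore expected to show a large step to a higher number, a 14-fold higher number from compound 3 to compound 4 (1.15 log units; beyond the scatter), and its value is estimated at 5000 nM, in the range 800 nM to 20000 nM.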

Compound 4, half-maximal inhibitory concentration: 1920 nM
Compound 4: the middle estimate sits 2.6-fold (0.42 log units) above what was measured; the range from low to high includes it.
By their numbers in this assay, from the lowest: compound 2; then compound 3; then compound 4. At a limit, above all of these: compound 1.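

With thiophen-3-yl held constant, the aromatic carbon next to the ring nitrogen now carries three measured groups in this assay: dimethylamino in place of methyl brings a 5.5-fold higher number from compound 3 to compound 4 (0.74 log units; beyond the scatter), and dimethylamino in place of methoxy brings a 15-fold higher number from compound 2 to compound 4 (1.17 log units; beyond the scatter), so the numbers rise from methoxy through methyl to dimethylamino. Dimethylamino alone does not place a compound at the limit, since with that group held constant, thiophen-3-yl in place of 1-benzofuran-2-yl brings an at least 10-fold lower number from compound 1 to compound 4 (1.01 log units; beyond the scatter). The value of compound 1 in that step is a limit and not a number: the limit of > 20000 nM in this assay, at which 1 of the 4 values shown sits.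

The compounds shown leave open whether this order holds with 1-benzofuran-2-yl in place of thiophen-3-yl. They also leave open where an amino or methylamino group on this carbon would fall relative to methyl and dimethylamino.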